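Aldehyde to carboxylic acid in an interleukin-2 inhibitor series

This account rests on a few compounds, and the source may have more. Where it says the series, first, only, none or still open, it means among the compounds named here.

compound 1 `Cn1nc(Cc2nnc(SCC(=O)Nc3ccc(Cl)cc3Cl)n2CCC=O)c2ccccc2c1=O`: 8600 nM in an assay on NK92 cells for inhibition of interleukin-2 (Homo sapiens), read by AlphaScreen, with stated times of 30 min and 1 h; on this read-out lower numbers stand for stronger inhibition and higher numbers for weaker inhibition
compound 2 `Cn1nc(Cc2nnc(SCC(=O)Nc3ccc(Cl)cc3Cl)n2CCC(=O)O)c2ccccc2c1=O`: > 30000 nM in this assay
compound 3 `Cn1c(Cc2nn(CCC=O)c(=O)c3ccccc23)nnc1SCCCCCCCC(=O)Nc1ccc(Cl)cc1Cl`: 21900 nM in this assay

The number for compound 2 is a limit of the assay, not a measured value. The change hydroxy in place of hydrogen on a carbonyl carbon gives an at least 3.4-fold higher number from compound 1 to compound 2 (0.54 log units; beyond the scatter); this rests on (the limit of > 30000 nM in this assay, at which 1 of the 3 values shown sits). Compound 3 shows a higher number than compound 1; the difference between the two cores is not broken down here. Compound 4 `Cn1c(Cc2nn(CCC(=O)O)c(=O)c3ccccc23)nnc1SCCCCCCCC(=O)Nc1ccc(Cl)cc1Cl` is not yet measured and arises from compound 3 by hydroxy in place of hydrogen on a carbonyl carbon, the same change as from compound 1 to compound 2. Compound 3 already gives 21900 nM, so compound 4 is expected to show a higher number still. The expected step is a 3.2-fold higher number from compound 3 to compound 4 (0.50 log units; beyond the scatter). Compound 4 is estimated at 70000 nM, within 25000 nM to 200000 nM.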

Compound 4, half-maximal inhibitory concentration: 30000 nM
For compound 4 the middle estimate is 2.3-fold (0.37 log units) above the measured one; measured number inside the range.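

On the core of compound 3, the change from 2-formylethyl to 2-carboxyethyl gives in this assay a 1.4-fold higher number from compound 3 to compound 4 (0.14 log units; within the scatter), so on this core no effect of the change can be read. This does not show that the change carries over from one core to the other at full size, nor does it show that the two cores respond differently: the same change on two cores in this assay, an at least 3.4-fold higher number (0.54 log units; beyond the scatter) from compound 1 to compound 2 and a 1.4-fold higher number (0.14 log units; within the scatter) from compound 3 to compound 4; the limit leaves it open whether they differ
As far as these compounds go, compound 2 gives > 30000 nM, which is a limit of the assay, so the size of the step on the first core remains unknown.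

Open, from the compounds shown here alone, is how an amine or a methyl ester in place of the formyl would read on either core. Also open, going by these compounds, is whether a carboxylic acid on a longer chain would behave like the 2-carboxyethyl group.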